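Fluoro in place of chloro: a small expected step

This account rests on a few compounds, and the source may have more. Where it says the series, first, only, none or still open, it means among the compounds named here.

compound 1 `Cc1cc(CNCc2ccccc2)c(C)n1-c1ccc(F)cc1`: 28 ug/mL
compound 2 `Cc1cc(CNOCc2ccccc2)c(C)n1-c1ccc(Cl)cc1`: 67 ug/mL

In an ADME assay on THP-1 cells (Homo sapiens) for cytotoxicity, read by trypan blue exclusion, with a stated time of 48 h (a lower number here means a stronger inhibitor of growth, a higher number a weaker inhibitor of growth), compound 2 gives the higher of the two numbers, 67 ug/mL, so it is the weaker inhibitor of growth, and its gap to compound 1 lies beyond the scatter. Compound 3 `Cc1cc(CNOCc2ccccc2)c(C)n1-c1ccc(F)cc1` is still unmeasured. It differs from compound 2 by fluoro in place of chloro on an aromatic carbon. The two measured compounds differ in more than one place, so neither value isolates this change. No step beyond the scatter is expected in this assay. The estimated change is a 1.1-fold lower number from compound 2 to compound 3 (0.05 log units; within the scatter). For compound 3 the expected value is 60 ug/mL, with an estimated range of 27 ug/mL to 130 ug/mL.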

Compound 3, concentration for 50% growth inhibition: 292 ug/mL
The estimate for compound 3 lay 4.9-fold (0.69 log units) below the measured number; measured number above the stated range.
By their numbers in this assay, from the lowest: compound 1; then compound 2; then compound 3.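

In this assay the change from 4-chlorophenyl to 4-fluorophenyl gives a 4.4-fold higher number from compound 2 to compound 3 (0.64 log units; beyond the scatter) and so shows that, at this position on the ring, one halogen cannot simply stand in for the other. With fluoro held constant, benzyloxy in place of benzyl on the amine nitrogen gives a 10-fold higher number from compound 1 to compound 3 (1.02 log units; beyond the scatter) and marks that nitrogen as a second place where the number moves. No measurement here explains either step. Still open, going by these compounds, is how bromo or methoxy at this ring position would read, and whether the halogen change would give a similar step with benzyl on the nitrogen.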